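The source may report more compounds than this note shows. Statements on the series, on what has been measured and on what is new or still open speak of the compounds shown alone.

Among the three compounds measured in a functional assay on the whole organism (strain Wistar albino) for inhibition, with Rattus norvegicus as the target, read by paw edema, with stated times of 1 h and 3 h, at a dose of 0.32 mmol/kg by the intraperitoneal route (on this read-out higher numbers stand for more inhibition at the one dose given (going by the name of the read-out) and lower numbers for less inhibition), compound 3 `Cc1ccc(-c2nn(-c3ccc(S(N)(=O)=O)cc3)cc2/C=N\c2ccccc2)cc1` gives 57.1%, the second highest of the three. Compound 2 `Cc1ccc(-c2nn(-c3ccc(Cl)cc3)cc2/C=N\c2ccc(Cl)cc2)cc1` gives 49.2%, a number that lies within the scatter of the value of compound 3. Compound 1 `Cc1ccc(-c2nn(-c3ccc(S(N)(=O)=O)cc3)cc2C=O)cc1` gives 68.2%, and the change a number 11.1 percentage points lower from compound 1 to compound 3 (beyond the scatter) is beyond the scatter. Compound 4 `Cc1ccc(-c2nn(-c3ccc(S(N)(=O)=O)cc3)cc2/C=N\c2ccc(Cl)cc2)cc1` differs from compound 3 by chloro in place of hydrogen on an aromatic carbon. Among the compounds with values here, no measured step isolates this change; compound 2 carries a chloro of the same kind but differs from compound 3 in a second place as well, so only the two values can be set side by side, and they lie within the scatter of each other. The step of a number 0.1 percentage points lower from compound 3 to compound 4 (within the scatter) is therefore expected to stay within the scatter. Compound 4 is estimated at 57%, between 46% and 68%.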

Compound 4, a percentage reported as inhibition, in the whole organism at one dose (the size of the read-out at that dose, not a potency): 78.4%
Compound 4: the middle estimate sits 21.4 percentage points below what was measured, and the stated range ends below it.
By their numbers in this assay, from the lowest: compounds 2 and 3 (each within the scatter of the next); then compound 1; then compound 4.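

In this assay, chloro in place of hydrogen at this place on the ring is a real change and not a silent one, giving a number 21.3 percentage points higher from compound 3 to compound 4 (beyond the scatter), while sulfamoyl in place of chloro with the 4-chlorophenyl group held constant gives a number 29.2 percentage points higher from compound 2 to compound 4 (beyond the scatter). The 4-chlorophenyl-bearing group also reverses the drop seen with the plain phenyl-bearing group, since replacing the group of compound 1 now gives a number 10.2 percentage points higher from compound 1 to compound 4 (beyond the scatter). Nothing available explains these rises. As far as these compounds go, whether fluoro, methoxy or an amine at the same place would give a similar rise remains open, as does whether it depends on chloro itself.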